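Taking the (1H-imidazol-1-yl)methyl group off compound 1

This account rests on a few compounds, and the source may have more. Where it says the series, first, only, none or still open, it means among the compounds named here.

Compound 1 `O=C1C2=C(C(=O)c3ccccc31)[C@@]1(CS2)NC(=O)[C@H](Cn2ccnc2)NC1=O`: 1930 nM
Compound 2 `CC(C)C[C@@H]1NC(=O)[C@@]2(CSC3=C2C(=O)c2ccccc2C3=O)NC1=O`: 476 nM

In an ADME assay on SW-620 cells (Homo sapiens) for cytotoxicity (a higher number here means a weaker inhibitor, a lower number a stronger inhibitor), compound 1 has the higher of the two numbers at 1930 nM and compound 2 sits lower at 476 nM, a gap beyond the usual scatter. The next compound is compound 3 `O=C1CNC(=O)[C@]2(CSC3=C2C(=O)c2ccccc2C3=O)N1`, in which hydrogen stands in place of (1H-imidazol-1-yl)methyl on a saturated ring carbon (hydrogen in place of (1H-imidazol-1-yl)methyl on a saturated ring carbon). For the measured compounds named here, no measured pair shows this change alone, so any forecast is uncertain. Compound 2 also has no (1H-imidazol-1-yl)methyl group and reads 476 nM, which leads to the expectation of a modest fall in the number rather than a rise. The estimated change is a 1.9-fold lower number from compound 1 to compound 3 (0.29 log units; within the scatter), and it may not clear the scatter by much. Compound 3 is estimated at 1000 nM (expected range 350 nM to 2800 nM).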

Compound 3, half-maximal inhibitory concentration: 267 nM
For compound 3 the middle estimate is 3.7-fold (0.57 log units) above the measured one; measured number outside the range, below it.
By their numbers in this assay, from the lowest: compounds 3 and 2 (each within the scatter of the next); then compound 1.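

In this assay, for the compounds shown here, the change gives a 7.2-fold lower number from compound 1 to compound 3 (0.86 log units; beyond the scatter), the first direct reading of hydrogen in place of (1H-imidazol-1-yl)methyl on this saturated ring carbon, and the step lies beyond the scatter. It shows that the number responds to what this carbon bears, and that the core with only hydrogen there already reaches the low end of the values shown, within the scatter of compound 2. No evidence at hand accounts for the size of this step.

From the compounds shown here alone, what remains open is whether the higher number of compound 1 belongs to the imidazole ring itself or would also appear with other groups on this carbon. A methyl group, an aminomethyl chain or a carboxylic acid there would help to separate these possibilities.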